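Swapping a Bicyclic Amide Cap for a Pyridazine

A few compounds are considered here, and "the series" means these few. Any claim that something is new, unique, unknown or untested is made for them only; others in the source may bear on it.

In an assay for activation of interferon regulatory factor 3 (Homo sapiens), read by a luciferase reporter, with a stated time of 20 h (on this read-out higher numbers stand for an effect only at larger amounts of compound and lower numbers for an effect already at smaller amounts), compound 1 `CCCn1c(NC(=O)c2cc(C)nn2CC)nc2cccc(OC)c21` gives > 100000 nM, which is a limit of the assay rather than a number. Compound 2 `CCCn1c(NC(=O)c2nccc3ccccc23)nc2cc(C(N)=O)cc(OC)c21` gives > 100000 nM in this assay, again a limit and not a measured value. Both measured compounds sit at the same edge of the assay, as captured by the limit of > 100000 nM in this assay, at which 2 of the 2 values shown sit. Compound 2 therefore stands at the limit, and no number separates it from compound 1. Compound 3 `CCCn1c(NC(=O)c2cccnn2)nc2cc(C(N)=O)cc(OC)c21` differs from compound 2 by a single change: pyridazin-3-yl in place of isoquinolin-1-yl on a carbonyl carbon. Among the compounds with values here, no step between measured compounds exists here, so the expectation rests only on where compound 2 sits. The step of a number no higher from compound 2 to compound 3 (the limit leaves the size open) is expected to be essentially none beyond the scatter. Compound 3 is accordingly estimated at 100000 nM, with a range from 20000 nM to 300000 nM, and a further limit is the likeliest outcome.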

Compound 3, half-maximal effective concentration: > 100000 nM
Compound 3: no number, only a limit; the forecaster's own chance of this, stated with the estimate: 75%; the middle value lies on the limit itself.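

Within the data shown here, compound 2 and compound 3 both stand at a limit of the assay rather than at a number, so no step between them can be read: the limit of > 100000 nM in this assay, at which 3 of the 3 values shown sit. The compounds shown leave open which structural change, if any, would give a measurable value in this assay.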